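Chalcone series: from compound 1 toward compound 3

The source may hold more compounds than are shown below. What is called first, only, known or untested is meant among the compounds shown, and "the series" means these compounds.

Measured compounds:
- compound 1, `O=C(/C=C/c1ccccc1Cl)c1ccc(OCc2ccccc2)cc1`: 99.7%
- compound 2, `Cc1ccc(COc2ccc(C(=O)/C=C/c3ccc(F)cc3)cc2)cc1`: 15.4%

In a functional assay on HCT-116 cells (Homo sapiens) for antiproliferative activity, read by sulforhodamine B assay, with a stated time of 3 days, tested at 50 uM (a lower number here means a weaker effect, a higher number a stronger effect of the compound at the concentration tested), compound 1 gives 99.7%, the higher of the two numbers, and compound 2 gives 15.4%, a far lower reading beyond the usual scatter. Going by the values given here, the two compounds differ in more than one place, so no single step between them can be read from these values.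

Compound 3, `COc1ccc(/C=C/C(=O)c2ccc(OCc3ccccc3)cc2)cc1`, keeps the core of compound 1 and changes one group: 4-methoxyphenyl in place of 2-chlorophenyl on a double-bonded chain carbon bound to a double-bonded chain carbon. Among the compounds with values here, no measured pair isolates this kind of change, so the expected step rests on the wide spread seen between compound 1 and compound 2 alone. Some loss is expected, with a step of a number 44.7 percentage points lower from compound 1 to compound 3 (beyond the scatter) in this assay. Compound 3 is therefore estimated at 55%, within a range from 15% to 95%.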

Compound 3, a percentage reported as inhibition, at one concentration (the size of the read-out at that concentration, not a potency): 13.2%
The estimate for compound 3 lay 41.8 percentage points above the measured number; measured number below the stated range.
By their numbers in this assay, from the lowest: compounds 3 and 2 (each within the scatter of the next); then compound 1.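

In this assay, putting 4-methoxyphenyl in place of 2-chlorophenyl on a double-bonded chain carbon bound to a double-bonded chain carbon gives a large step, a number 86.5 percentage points lower from compound 1 to compound 3 (beyond the scatter), while the rest of the core of compound 1 stays the same. Going by these compounds alone, this is the first change that can be read at a single place, and it shows that the group here can alone turn a very high reading into a low one at the concentration tested. Nothing available explains why these two groups read so differently.

The swap changes both the atom attached to the ring and its place there, so the compounds shown leave open which of the two matters. A 2-methoxyphenyl or 4-chlorophenyl group would separate these, and a group with an amine, such as 4-aminophenyl, would show how far this position tolerates a different kind of group.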